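The source may report more compounds than this note shows. Statements on the series, on what has been measured and on what is new or still open speak of the compounds shown alone.

Values in a functional assay on A549 cells (Homo sapiens) for cytotoxicity, read by MTT assay, with a stated time of 48 h; a higher number here means a weaker inhibitor, a lower number a stronger inhibitor:
- compound 1 `COc1ccc(-c2nc3ccccn3c2C(=O)/C=C\Nc2ccc3[nH]ccc3c2)cc1`: 11000 nM
- compound 2 `COc1ccc(-c2nc3ccccn3c2C(=O)/C=C\Nc2ccc3cc[nH]c3c2)cc1`: 8800 nM
- compound 3 `COc1ccc(-c2nc3ccccn3c2C(=O)/C=C\Nc2cnc3ccccc3c2)cc1`: 1050 nM

Compound 3 has the lowest of the three numbers, and both steps leading to it lie beyond the scatter: a 10-fold lower number from compound 1 to compound 3 (1.02 log units; beyond the scatter) and an 8.4-fold lower number from compound 2 to compound 3 (0.92 log units; beyond the scatter). Compound 4 `COc1ccc(-c2nc3ccccn3c2C(=O)/C=C\Nc2ccc3ncccc3c2)cc1` carries quinolin-6-yl in place of quinolin-3-yl on an amine nitrogen.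

Among the compounds with values here, the nearest precedent is the swap of 1H-indol-5-yl for 1H-indol-6-yl, a 1.3-fold lower number from compound 1 to compound 2 (0.10 log units; within the scatter), which stayed within the scatter. The two larger steps show that this group can matter, but neither compares two quinolinyl groups. Within the data shown here, a small rise is therefore expected, with no step clearly beyond the scatter. The estimated step in this assay is a 1.6-fold higher number from compound 3 to compound 4 (0.21 log units; within the scatter). For compound 4 the estimate is 1700 nM, with an expected range of 550 nM to 5500 nM.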

Compound 4, half-maximal inhibitory concentration: 1210 nM
Compound 4: the middle estimate sits 1.4-fold (0.15 log units) above what was measured, and the stated range covers the measured number.
By their numbers in this assay, from the lowest: compounds 3 and 4 (each within the scatter of the next); then compounds 2 and 1 (each within the scatter of the next).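

Two quinolinyl groups can now be compared on the amine nitrogen in this assay, and the swap gives a 1.2-fold higher number from compound 3 to compound 4 (0.06 log units; within the scatter), so these two attachment points are not told apart here. The lower numbers relative to the indolyl compounds are not confined to quinolin-3-yl, since quinolin-6-yl also gives a 7.3-fold lower number from compound 2 to compound 4 (0.86 log units; beyond the scatter) and a 9.1-fold lower number from compound 1 to compound 4 (0.96 log units; beyond the scatter). No measurement is available to explain the separation between the quinolinyl and indolyl groups.

Open, as far as these compounds go, is whether naphthalen-2-yl, with carbon in place of the ring nitrogen, would keep the lower numbers. Also open, from the compounds shown here alone, is whether quinolin-2-yl or quinolin-8-yl would match quinolin-3-yl and quinolin-6-yl.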